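This account rests on a few compounds, and the source may have more. Where it says the series, first, only, none or still open, it means among the compounds named here.

Within the data shown here, compound 2, `CCOC(=O)CCCCCOc1cccc(CN(C(=O)c2ccc(-c3ccc(Cl)c(Cl)c3)cc2)C(C)C)c1`, is one of two compounds measured in an ADME assay on Raji cells (Homo sapiens) for cytotoxicity, read by CellTiter-Glo and resazurin assay, with a stated time of 72 h; a higher number here means that more compound is needed for the effect, a lower number that less compound is needed. In this assay compound 2 gives > 26000 nM, which is a limit of the assay rather than a number. The other measured compound, compound 1, `CCOC(=O)CCCCCOc1cccc(CN(C(=O)c2ccc(-c3cccc(NC(C)=O)c3)cc2)C(C)C)c1`, stands at the same kind of limit. In this assay compound 1 gives > 26000 nM, again a limit and not a number. The step that the two limits leave unreadable from compound 1 to compound 2 therefore cannot be read, as both values rest at the limit of > 26000 nM in this assay, at which 2 of the 2 values shown sit. Compound 3, `CCOC(=O)CCCCCOc1cccc(CN(C(=O)c2ccc(-c3cccc(S(C)(=O)=O)c3)cc2)C(C)C)c1`, differs from compound 2 in one place: 3-(methylsulfonyl)phenyl in place of 3,4-dichlorophenyl on an aromatic carbon. Among the measured compounds shown here, no measured step bears directly on this change; the single step available, from compound 1 to compound 2, is unreadable in size and direction, so nothing can be taken from it. The expectation rests only on both measured compounds remaining at the limit. The step from compound 2 to compound 3 in this assay is therefore expected to be a step that the limit leaves unreadable from compound 2 to compound 3, with no movement beyond the scatter foreseen. Compound 3 is estimated to give 40000 nM, within a range from 15000 nM to 120000 nM, and most likely reported again only as a limit.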

Compound 3, half-maximal effective concentration: > 26000 nM
Compound 3 was reported as a limit; the forecaster's own chance of this, stated with the estimate: 80%; the middle value does not contradict the limit.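

No step can be read between compound 1, compound 2 and compound 3 in this assay, since each value is a limit and not a number: (the limit of > 26000 nM in this assay, at which 3 of the 3 values shown sit). The compounds shown leave open how much of any of them is needed for the effect, and whether changing the substituted phenyl group alters that amount at all.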